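This account rests on a few compounds, and the source may have more. Where it says the series, first, only, none or still open, it means among the compounds named here.

Measured in a functional assay on NRK-49F cells (Rattus norvegicus) for cytotoxicity, read by MTT assay, with a stated time of 24 h; on this read-out lower numbers stand for stronger inhibition and higher numbers for weaker inhibition:
- compound 1 `C/C(=N\NC(=O)/C(C#N)=C/c1ccc(O)cc1)c1c(O)c2ccc(O)cc2oc1=O`: 61300 nM
- compound 2 `C/C(=N\NC(=O)/C(C#N)=C/c1ccc(Br)cc1)c1c(O)c2ccc(O)cc2oc1=O`: 49600 nM

Within the data shown here, compound 2 cannot be separated from the only other measured compound, with a 1.2-fold lower number from compound 1 to compound 2 (0.09 log units; within the scatter). Compound 3 `C/C(=N\NC(=O)/C(C#N)=C/c1ccc([N+](=O)[O-])cc1)c1c(O)c2ccc(O)cc2oc1=O` has nitro in place of bromo on an aromatic carbon, para to a large group: nitro in place of bromo on an aromatic carbon. Among the measured compounds shown here, only one measured step bears on this aromatic carbon, and it stayed small. No step beyond the scatter is therefore expected in this assay, and no direction can be given. The expected result is a 1.0-fold higher number from compound 2 to compound 3 (0.00 log units; within the scatter). For compound 3 the estimated value is 50000 nM, with an expected range of 25000 nM to 95000 nM.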

Compound 3, half-maximal inhibitory concentration: 43200 nM
Compound 3: the middle estimate sits 1.2-fold (0.06 log units) above what was measured; the range from low to high includes it.
By their numbers in this assay, from the lowest: compounds 3, 2 and 1 (each within the scatter of the next).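

In this assay the change from 4-bromophenyl to 4-nitrophenyl gives a 1.1-fold lower number from compound 2 to compound 3 (0.06 log units; within the scatter) and the change from hydroxy to nitro gives a 1.4-fold lower number from compound 1 to compound 3 (0.15 log units; within the scatter) at the same aromatic carbon. This carbon, para to a large group, has now carried hydroxy, bromo and nitro with no separable difference in this read-out. Nothing measured here accounts for this flat result.

Going by these compounds, whether an amine, a carboxylic acid or a longer chain at this carbon would also stay within the scatter remains open. The role of the shared core also remains open, since all of these compounds carry it unchanged.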